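Aminobenzyl sulfamides: methyl to methoxy exchange

This account rests on a few compounds, and the source may have more. Where it says the series, first, only, none or still open, it means among the compounds named here.

Compound 1 `Cc1ccc(CNS(=O)(=O)N2CCN(/C(C=N)=C(\OCC3(C)CC3)C(=O)Nc3cccc(Cl)c3)CC2)cc1N` gives 1410 ng.h/mL in an ADME assay on the whole organism (plasma) for pharmacokinetics, with Rattus norvegicus as the target, with a stated time of 6 h, at a dose of 10 mg/kg by the oral route; a lower number here means less compound in the circulation, a higher number more compound in the circulation at the dose given. Compound 2 `COc1ccc(CNS(=O)(=O)N2CCN(/C(C=N)=C(\OCC3(C)CC3)C(=O)Nc3cccc(Cl)c3)CC2)cc1N` gives 440 ng.h/mL in this assay, and compound 3 `Cc1cc(CNS(=O)(=O)N2CCN(/C(C=N)=C(\OCC3(C)CC3)C(=O)Nc3cccc(Cl)c3)CC2)ccc1N` gives 900 ng.h/mL. The cores of compound 1 and compound 3 differ as 4-amino-3-methylphenyl in place of 3-amino-4-methylphenyl on a saturated chain carbon bound to a sulfonamide nitrogen, which made a step of a 1.6-fold lower number from compound 1 to compound 3 (0.19 log units; within the scatter). The change methoxy in place of methyl on an aromatic carbon brought a 3.2-fold lower number from compound 1 to compound 2 (0.51 log units; beyond the scatter). Compound 4 `COc1cc(CNS(=O)(=O)N2CCN(/C(C=N)=C(\OCC3(C)CC3)C(=O)Nc3cccc(Cl)c3)CC2)ccc1N` carries the same kind of change, (methoxy in place of methyl on an aromatic carbon); the place is meta to a large group, whereas in compound 1 it is para to a large group. Going by the values given here, the step is expected at a 3.0-fold lower number from compound 3 to compound 4 (0.48 log units; beyond the scatter), resting on the single earlier example, the step compound 1 made, a 3.2-fold lower number from compound 1 to compound 2 (0.51 log units; beyond the scatter). Compound 4 is accordingly estimated at 300 ng.h/mL, with the expected range from 120 ng.h/mL to 750 ng.h/mL.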

Compound 4, area under the concentration-time curve: 860 ng.h/mL
Compound 4: the middle estimate sits 2.9-fold (0.46 log units) below what was measured; the whole stated range lies below it.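

Methoxy in place of methyl on an aromatic carbon does not carry from one core to the other at the same size in this assay: the same change on two cores in this assay, a 3.2-fold lower number (0.51 log units; beyond the scatter) from compound 1 to compound 2 and a 1.0-fold lower number (0.02 log units; within the scatter) from compound 3 to compound 4, 3.1-fold (0.49 log units) apart, beyond the scatter of two such steps
Where the methoxy stands ortho to an amino group and meta to a large group, the change gives a 1.0-fold lower number from compound 3 to compound 4 (0.02 log units; within the scatter) and the steps of a 2.0-fold higher number from compound 2 to compound 4 (0.29 log units; within the scatter) and a 1.6-fold lower number from compound 1 to compound 4 (0.21 log units; within the scatter) leave the new compound not set apart from either. Two cores show that the step does not transfer, but not what sets the size of the step. From the compounds shown here alone, whether ethoxy or fluorine in the same place would follow compound 2 or compound 4 stays open. So does whether a third arrangement of the amino group and the methyl would behave like compound 1 or compound 3.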